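A few compounds are considered here, and "the series" means these few. Any claim that something is new, unique, unknown or untested is made for them only; others in the source may bear on it.

Compound 1 `Clc1nc(-c2ccccc2)cs1` is a chloro-bearing member of a small set tested in an assay on isolated protein for inhibition of Indoleamine 2,3-dioxygenase 1 (Homo sapiens), read by colorimetric assay, with stated times of 10 min and 30 min, tested at 100 uM (a higher number here means more inhibition at the concentration tested (going by the name of the read-out), a lower number less inhibition), where compound 1 gives 0.5%. Among the three measured values it stands second highest. Its closest neighbour is compound 3 `COc1ccc(-c2c[nH]c(=S)s2)cc1`, which gives 0%; the gap between these two lies within the scatter. The value furthest from it belongs to compound 2 `S=c1[nH]cc(-c2ccccc2)s1`, which in this assay gives 16%, a gap beyond the scatter. For the measured compounds named here, the only single-point step between measured compounds runs a number 16 percentage points lower from compound 2 to compound 3 (beyond the scatter), and that step concerns a methoxy group on the phenyl ring, not the substituent on the core.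

Compound 4 `Brc1nc(-c2ccccc2)cs1` differs from compound 1 by a single exchange: bromo in place of chloro on an aromatic carbon. Going by the values given here, no measured step compares bromo with chloro, so no guide to its effect exists here. In the absence of such a step, compound 4 is expected to behave much like compound 1, with the step of a number 0.5 percentage points higher from compound 1 to compound 4 (within the scatter) expected to stay within the scatter. For compound 4, the estimated value in this assay is 1%, with a likely range from -6% to 9%.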

Compound 4, a percentage reported as inhibition, at one concentration (the size of the read-out at that concentration, not a potency): 12%
For compound 4 the middle estimate is 11 percentage points below the measured one, and the stated range ends below it.
By their numbers in this assay, from the lowest: compounds 3 and 1 (each within the scatter of the next); then compounds 4 and 2 (each within the scatter of the next).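

On the aromatic carbon next to the ring nitrogen and next to the ring sulfur, bromo in place of chloro gives, in this assay, a number 11.5 percentage points higher from compound 1 to compound 4 (beyond the scatter). This position therefore distinguishes between these two halogens, even though each counts as a single heavy atom with no hydrogen-bond donors or acceptors and no net charge, a sensitivity that the earlier step on the phenyl ring of a different core could not reveal. Nothing available here accounts for the difference between chloro and bromo.

As far as these compounds go, a single exchange sets no trend, so it remains open whether iodo would extend the rise or fluoro reverse it. From the compounds shown here alone, how an amine, a nitrile or a longer chain on this carbon would read out also remains open.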